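The source may report more compounds than this note shows. Statements on the series, on what has been measured and on what is new or still open speak of the compounds shown alone.

In a functional assay on SW620/5-FU cells (Homo sapiens) for cytotoxicity, read by MTT assay, with a stated time of 48 h, in the presence of a further agent that is not named here (a lower number here means that less compound is needed, a higher number that more compound is needed for the effect), compound 1 (`COc1ccc(-c2cc(NNC(=O)Nc3cc(Cl)nc(OC(C)C)c3)nc3c2cnn3C)cc1`) gives 47100 nM, compound 2 (`Cn1ncc2c(-c3ccc(F)cc3)cc(NNC(=O)Nc3cc(Cl)cc(Cl)c3)nc21`) gives 54300 nM and compound 3 (`CCCc1cc(NNC(=O)Nc2cc(Cl)nc(Cl)c2)nc2c1cnn2C`) gives 38700 nM. Compound 2 therefore stands within the usual scatter of both other compounds, although no two of the three differ in only one place. Compound 4 (`Cn1ncc2c(-c3ccc(F)cc3)cc(NNC(=O)Nc3cc(F)cc(F)c3)nc21`) has not yet been measured. It carries 3,5-difluorophenyl in place of 3,5-dichlorophenyl on an amide-type nitrogen. Among the measured compounds shown here, the data hold no measured step for this change, so the expectation starts from compound 2 at 54300 nM. The estimated change is a 1.1-fold higher number from compound 2 to compound 4 (0.04 log units; within the scatter), which is expected to stay within the scatter. For compound 4 the expected value is 60000 nM, with an estimated range of 28000 nM to 125000 nM.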

Compound 4, half-maximal effective concentration: 47400 nM
Compound 4: middle estimate off by 1.3-fold (0.10 log units), on the high side, within the range that was stated.
By their numbers in this assay, from the lowest: compounds 3, 1, 4 and 2 (each within the scatter of the next).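

Among the compounds shown here, with a 1.1-fold lower number from compound 2 to compound 4 (0.06 log units; within the scatter) in this assay, the series gains its only comparison between compounds that differ in one place. On this amide-type nitrogen, 3,5-difluorophenyl and 3,5-dichlorophenyl cannot be told apart in this assay. Nothing available explains this result.

On these data alone, it remains open whether a phenyl ring carrying an amine or a carboxylic acid at this position would give a number beyond the scatter. As far as these compounds go, whether the same exchange would read alike with the other groups on the shared core also remains open.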